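This account rests on a few compounds, and the source may have more. Where it says the series, first, only, none or still open, it means among the compounds named here.

Measured so far in a functional assay on a cell-free system (plasma, Homo sapiens) for inhibition, with Plasma (Rattus norvegicus) as the target; on this read-out higher numbers stand for weaker inhibition and lower numbers for stronger inhibition
compound 1 `O=c1cc(N2CCNCC2)c2ccccc2o1` - 49000 nM
compound 2 `Cc1c(OCc2ccccc2)ccc2c(N3CCNCC3)cc(=O)oc12` - 1900 nM
compound 3 `O=c1cc(N2CCNCC2)c2cc(OCc3cccnc3)ccc2o1` - 38000 nM

Compound 2 (1900 nM) has the lowest number of the three and is the strongest inhibitor here. Compound 1 and compound 3 lie within the scatter of each other, both well above compound 2.

Compound 4 `CCOCOc1ccc2c(N3CCNCC3)cc(=O)oc2c1C` departs from compound 2 by ethoxy in place of phenyl on a saturated chain carbon bound to an oxygen on an aromatic ring, which turns benzyloxy into ethoxymethoxy.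

Among the compounds with values here, only one measured step bears on this change, and only loosely: a 1.3-fold lower number from compound 1 to compound 3 (0.11 log units; within the scatter). It shows that adding (pyridin-3-yl)methoxy to compound 1 moved this assay by no more than the scatter. Within the data shown here, no measured step isolates the loss of the phenyl, so the low number of compound 2 (1900 nM) cannot be assigned to the benzyloxy group. A moderate move towards a higher number, meaning weaker inhibition, seems the likeliest outcome, though no change is not excluded.

The expected size of the move is a 2.6-fold higher number from compound 2 to compound 4 (0.42 log units; beyond the scatter).
For compound 4 the estimated value is 5000 nM, with an expected range of 1500 nM to 20000 nM.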

Compound 4, half-maximal inhibitory concentration: 1800 nM
Compound 4: the middle estimate sits 2.8-fold (0.44 log units) above what was measured; measured number inside the range.
By their numbers in this assay, from the lowest: compounds 4 and 2 (each within the scatter of the next); then compounds 3 and 1 (each within the scatter of the next).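

In this assay the step from benzyloxy to ethoxymethoxy, which reads as a 1.1-fold lower number from compound 2 to compound 4 (0.02 log units; within the scatter), shows that phenyl on this saturated chain carbon can give way to ethoxy with no change beyond the scatter. For this pair, the six-membered aromatic ring of the benzyloxy group is therefore not needed to hold the level of compound 2, and a chain with no ring and one hydrogen-bond acceptor serves equally well on this read-out. No supporting evidence bears on why the two groups read alike.

On these data alone, the part played by the methyl group on the core of compound 2 and compound 4 stays open. So does whether a longer chain, an amine or a carboxylic acid at the end of this chain would hold the same level.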